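Furan-2-yl in place of 1H-imidazol-5-yl on the shared core

This account rests on a few compounds, and the source may have more. Where it says the series, first, only, none or still open, it means among the compounds named here.

In a functional assay on KB cells (Homo sapiens) for cytotoxicity (on this read-out lower numbers stand for an effect already at smaller amounts and higher numbers for an effect only at larger amounts of compound), compound 1 `Cn1ccnc1/C=N/Nc1ccnc2cc(Cl)ccc12` gives 17.1 uM, compound 2 `Clc1ccc2c(N/N=C/c3cnc[nH]3)ccnc2c1` gives 29.1 uM and compound 3 `Cn1cncc1/C=N/Nc1ccnc2cc(Cl)ccc12` gives 73.8 uM. The position of compound 2 among these shows in two steps: a 1.7-fold higher number from compound 1 to compound 2 (0.23 log units; within the scatter) and a 2.5-fold higher number from compound 2 to compound 3 (0.40 log units; beyond the scatter). Compound 4 `Clc1ccc2c(N/N=C/c3ccco3)ccnc2c1` has furan-2-yl in place of 1H-imidazol-5-yl on a carbon with a double bond to nitrogen. Among the compounds with values here, no measured step introduces furan-2-yl, so the nearest guide is the exchange among the imidazolyl groups, where the widest step is a 4.3-fold higher number from compound 1 to compound 3 (0.64 log units; beyond the scatter). No step beyond the scatter is therefore expected, and no direction is favoured. The expected change is a 1.2-fold lower number from compound 2 to compound 4 (0.07 log units; within the scatter). Compound 4 is estimated at 25 uM, within an expected range from 9 uM to 70 uM.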

Compound 4, concentration for half-maximal effect: 19.9 uM
Compound 4: the middle estimate sits 1.3-fold (0.10 log units) above what was measured, and the stated range covers the measured number.
By their numbers in this assay, from the lowest: compounds 1, 4 and 2 (each within the scatter of the next); then compound 3.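

In this assay, within the data shown here, the first group here without a ring nitrogen, furan-2-yl, fits on the carbon with a double bond to nitrogen without leaving the scatter of two imidazolyl compounds: a 1.5-fold lower number from compound 2 to compound 4 (0.17 log units; within the scatter) and a 1.2-fold higher number from compound 1 to compound 4 (0.07 log units; within the scatter). Ring nitrogen is thus not needed at this place, and 1-methyl-1H-imidazol-5-yl remains apart, with a 3.7-fold lower number from compound 3 to compound 4 (0.57 log units; beyond the scatter). No available evidence accounts for these steps. Still open, on these data alone, is how a phenyl or thiophen-2-yl ring would read here, and whether an amine or a carboxylic acid on the furan ring would shift the number.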